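A Selenium-Bearing Group Replaces Methylsulfanyl on the Shared Core

The compounds below may be only part of what the source reports. "The series", "measured", "known", "first", "only" and "open" are said of these compounds alone.

Two measured compounds frame this account. Compound 1 `CS/C(=N\C(=O)c1sccc1Cl)NC(=O)c1sccc1Cl` and compound 2 `CS/C(=N\C(=O)c1csc([N+](=O)[O-])c1)NC(=O)c1csc([N+](=O)[O-])c1` share the same acyl-imidothioate core, differing only in the substituents on their thiophene rings. In a functional assay on K562 cells (Homo sapiens) for cytotoxicity, read by MTT assay, with a stated time of 72 h (a higher number here means a weaker inhibitor of growth, a lower number a stronger inhibitor of growth), compound 1 gives 78900 nM, and compound 2 gives 98700 nM; the two values lie within the scatter of each other, so neither can be called the stronger inhibitor, and compound 2 simply sits alongside compound 1 at weak growth inhibition.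

Compound 3 `O=C(/N=C(/NC(=O)c1csc([N+](=O)[O-])c1)[Se]Cc1ccccc1)c1csc([N+](=O)[O-])c1` keeps the nitrothiophene carbonyl groups of compound 2 and changes the central carbon: a group of 8 heavy atoms (7 carbon, 1 selenium; one six-membered aromatic ring of carbon only) in place of a group of 2 heavy atoms (1 carbon, 1 sulfur; no ring), on a carbon with a double bond to nitrogen. Among the compounds with values here, no measured pair shows what such a change does here, so its size has to be estimated. Compound 3 is expected to give a somewhat lower number than compound 2, by a step of a 3.3-fold lower number from compound 2 to compound 3 (0.52 log units; beyond the scatter), with the estimate for compound 3 in this assay at 30000 nM, within a range from 8000 nM to 100000 nM.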

Compound 3, concentration for total growth inhibition: 55800 nM
For compound 3 the middle estimate is 1.9-fold (0.27 log units) below the measured one; the measured number falls inside the stated range.
By their numbers in this assay, from the lowest: compounds 3, 1 and 2 (each within the scatter of the next).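

In this assay, this first step at the carbon with a double bond to nitrogen is a 1.8-fold lower number from compound 2 to compound 3 (0.25 log units; within the scatter). The position thus takes a group of 8 heavy atoms with a six-membered aromatic ring in place of methylsulfanyl, with no difference from compound 2 that can be told from the scatter of the assay. Nothing available offers an explanation for this outcome.

Because the exchange alters both the atom bound to this carbon and the size of the group, the compounds shown cannot separate the contribution of selenium from that of the aromatic ring. On these data alone, it also remains open how an amine or a longer alkyl chain on selenium would read at this position, and whether any such group would give a step beyond the scatter.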